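The source may report more compounds than this note shows. Statements on the series, on what has been measured and on what is new or still open speak of the compounds shown alone.

Among the compounds with values here, compound 3 `CCC(C)(C)Cc1c[nH]c(CCc2ccc(-n3ccnn3)cc2)n1` gives the highest number of the three measured members. In a functional assay on HEK293 cells for agonist activity at Bombesin receptor subtype-3 (Mus musculus), read by luminescence and calcium flux, with a stated time of 10 min (a higher number here means that more compound is needed for the effect, a lower number that less compound is needed), compound 3 gives 57 nM, whereas compound 2 `CCC(C)(C)Cc1c[nH]c(CCc2ccc(-n3ncnn3)cc2)n1` gives 25 nM and compound 1 `CCC(C)(C)Cc1c[nH]c(CCc2ccc(-c3ccncc3)cc2)n1` gives 15 nM. The step of a 3.8-fold higher number from compound 1 to compound 3 (0.58 log units; beyond the scatter) and the step of a 2.3-fold higher number from compound 2 to compound 3 (0.36 log units; beyond the scatter) both lie beyond the scatter, while the step of a 1.7-fold higher number from compound 1 to compound 2 (0.22 log units; within the scatter) does not. Compound 4 `CCC(C)(C)Cc1c[nH]c(CCc2ccc(-c3cnccn3)cc2)n1` has not yet been measured; it differs from compound 3 by pyrazin-2-yl in place of 1H-1,2,3-triazol-1-yl on an aromatic carbon. Within the data shown here, of the measured steps, the one from compound 1 to compound 3 bears most directly on this change, as compound 1 carries pyridin-4-yl on the same carbon of the shared core, and the step of a 3.8-fold higher number from compound 1 to compound 3 (0.58 log units; beyond the scatter) was modest but beyond the scatter, with the five-membered ring giving the higher number. The step from compound 2 to compound 3, a 2.3-fold higher number from compound 2 to compound 3 (0.36 log units; beyond the scatter), points the same way. Returning to a six-membered ring is therefore expected to lower the number, and compound 4 is expected to show a step of a 2.9-fold lower number from compound 3 to compound 4 (0.45 log units; beyond the scatter) in this assay. Compound 4 is accordingly estimated at 20 nM, with a range from 8 nM to 50 nM.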

Compound 4, half-maximal effective concentration: 11 nM
The estimate for compound 4 lay 1.8-fold (0.26 log units) above the measured number; measured number inside the range.
By their numbers in this assay, from the lowest: compounds 4, 1 and 2 (each within the scatter of the next, the first and the last beyond it); then compound 3.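

At the position on an aromatic carbon of a six-membered aromatic ring of carbon only, para to a large group, compound 4 shows in this assay that exchanging the 1H-1,2,3-triazol-1-yl group for pyrazin-2-yl gives a 5.2-fold lower number from compound 3 to compound 4 (0.71 log units; beyond the scatter), so a second kind of six-membered ring now stands apart from this five-membered ring. The two six-membered rings cannot be told apart here, with a 1.4-fold lower number from compound 1 to compound 4 (0.13 log units; within the scatter), which suggests that this position accepts more than the pyridin-4-yl group alone. The result also separates the 2H-tetrazol-2-yl group from pyrazin-2-yl, with a 2.3-fold lower number from compound 2 to compound 4 (0.36 log units; beyond the scatter), yet compound 2 goes against a clean division by ring size, since a 1.7-fold higher number from compound 1 to compound 2 (0.22 log units; within the scatter) stays unresolved.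

The compounds shown leave open whether ring size or the count of hetero atoms goes with these steps, as the groups differ in both at once, and where a plain phenyl ring or a primary amine on the same carbon would fall. No measurement given here accounts for the differences among these groups.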